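The compounds below may be only part of what the source reports. "The series", "measured", "known", "first", "only" and "open" are said of these compounds alone.

Of the compounds shown here, three have so far been tested for their ability to block a receptor protein in an assay on isolated protein for inhibition of vitamin D3 receptor (Homo sapiens), read by fluorescence polarization; on this read-out higher numbers stand for weaker inhibition and lower numbers for stronger inhibition. Compound 1 `CN(Cc1ccccc1F)C(=O)C1CCN(C(=O)c2ccc(S(C)(=O)=O)c([N+](=O)[O-])c2)CC1` gives > 60000 nM, which is a limit rather than a number. Compound 3 `CN(Cc1cccc(F)c1)C(=O)CNC(=O)c1ccc(S(C)(=O)=O)c([N+](=O)[O-])c1` likewise gives > 60000 nM, again a limit. Compound 2 `CN(CC(=O)N1CCN(c2ccc(F)cc2)CC1)C(=O)c1ccc(S(C)(=O)=O)c([N+](=O)[O-])c1` gives > 60000 nM, also a limit. Compound 2 thus stands exactly where everything measured so far stands: all three results sit at the limit of > 60000 nM in this assay, at which 3 of the 3 values shown sit, and no order among them can be drawn. Among the measured compounds shown here, no two measured compounds differ in just one place, so there is no measured step to lean on.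

Compound 4 `CN(CC(=O)N1CCN(c2ccc(C(F)(F)F)cc2)CC1)C(=O)c1ccc(S(C)(=O)=O)c([N+](=O)[O-])c1` is not yet measured. It differs from compound 2 by trifluoromethyl in place of fluoro on an aromatic carbon, in words trifluoromethyl in place of fluoro on an aromatic carbon. With every measured value at a limit, no direction can be read from the data, and the step is expected to be none beyond the scatter, most probably a further limit. Compound 4 is therefore estimated at 80000 nM, within 30000 nM to 300000 nM. The expected step is a step that the limit leaves unreadable from compound 2 to compound 4.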

Compound 4, half-maximal inhibitory concentration: > 60000 nM
Compound 4 was reported as a limit; the forecaster's own chance of this, stated with the estimate: 85%; the middle value does not contradict the limit.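

Compound 2 and compound 4 are both reported only as limits, not as numbers, so no step between them can be read: the limit of > 60000 nM in this assay, at which 4 of the 4 values shown sit.

The compounds shown leave open whether trifluoromethyl in place of fluoro changes inhibition at all, and which structural change would bring a measurable value.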